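Stereochemical inversion at the ring hydroxyl carbon, compound 2 to 3

The source may hold more compounds than are shown below. What is called first, only, known or untested is meant among the compounds shown, and "the series" means these compounds.

Measured compounds:
compound 1, `N#Cc1cnc(NCc2cnccc2C(F)(F)F)cc1N[C@H]1CC[C@@H](C(N)=O)CC1`, 400 nM
compound 2, `CC1(C)[C@@H](O)C[C@H]1Nc1nc(NCc2cnccc2C(F)(F)F)ncc1C#N`, 600 nM

Of the compounds shown here, two have been measured in an assay on isolated protein for inhibition of protein kinase C delta type (Homo sapiens), read by TR-FRET, with a stated time of 2 h; on this read-out lower numbers stand for stronger inhibition and higher numbers for weaker inhibition. Compound 1 gives 400 nM and compound 2 gives 600 nM. Compound 2 therefore holds the higher of the two numbers, but the gap to compound 1 lies within the scatter of the assay, so the two cannot be placed in order of strength on these data. Among the measured compounds shown here, no pair of measured compounds differs in one place, so no measured step exists to lean on.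

The next compound, compound 3, `CC1(C)[C@@H](Nc2nc(NCc3cnccc3C(F)(F)F)ncc2C#N)C[C@@H]1O`, is the epimer of compound 2: the two compounds have the same atoms and bonds and differ only in configuration as drawn: 1 of 2 stereo elements differ; a stereocentre at a saturated ring carbon is drawn R in compound 2 and S in compound 3. The hydroxyl-bearing carbon of the cyclobutane ring carries the inverted configuration while everything else is kept. For the measured compounds named here, with no comparable stereo step in hand, the expectation is a step from compound 2 to compound 3 of a 1.7-fold higher number from compound 2 to compound 3 (0.22 log units; within the scatter), of moderate size and in the direction of a weaker result, with a genuine possibility of no change beyond the scatter. The expected value for compound 3 in this assay is 1000 nM, within a range of 300 nM to 3500 nM.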

Compound 3, half-maximal inhibitory concentration: 2000 nM
Compound 3: middle estimate off by 2.0-fold (0.30 log units), on the low side; measured number inside the range.
By their numbers in this assay, from the lowest: compounds 1 and 2 (each within the scatter of the next); then compound 3.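

In this assay, among the compounds shown here, inversion at the saturated ring carbon gives a 3.3-fold higher number from compound 2 to compound 3 (0.52 log units; beyond the scatter), the first measured step and the first separation beyond the scatter, with the drawn R configuration holding the lower number. The step can be assigned to this one stereocentre, a link that the comparison of compound 1 with compound 2 could not provide: the fact that compounds 2 and 3 differ only in the configuration as drawn. The step is modest, so at this position the S configuration weakens inhibition without abolishing it, and compound 3 still gives a measurable 2000 nM.

On these data alone, whether the same preference holds with an amine or a methyl ether in place of the hydroxyl stays open, as does the contribution of the second stereocentre, which is drawn the same in compound 2 and compound 3. A single pair also gives no reason for the difference between the two configurations and no basis for carrying it over to other substituents on the shared core.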